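The source may report more compounds than this note shows. Statements on the series, on what has been measured and on what is new or still open speak of the compounds shown alone.

Of the compounds shown here, two with a shared core have been measured in a functional assay on HCT-116 cells (Homo sapiens) for antiproliferative activity, read by MTT assay, with a stated time of 72 h (a higher number here means a weaker inhibitor, a lower number a stronger inhibitor), so far. Compound 1 `COc1ccc(OCCCON2C(N)=NC(N)=NC23CCOCC3)cc1` gives 1500 nM in this assay, the highest of the two numbers, which means it is the weaker inhibitor of the pair. Compound 2 `NC1=NC2(CCSCC2)N(OCCCOc2ccccc2Cl)C(N)=N1` gives 1 nM in this assay, a far lower number and a gap well beyond the usual scatter; compound 2 differs from compound 1 in more than one place, so no single change can be read from that gap.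

Compound 3 `NC1=NC2(CCOCC2)N(OCCCOc2cccc(Cl)c2)C(N)=N1` has not yet been measured. It differs from compound 1 in one place: 3-chlorophenyl in place of 4-methoxyphenyl on an oxygen on a saturated carbon. Compound 2 also carries a chlorine on its aromatic ring, as its structure shows, and that is the only hint here of what a chlorine in this part of the molecule may do.

On that basis a drop in the number, beyond the scatter, is expected, with the step from compound 1 to compound 3 estimated at a 50-fold lower number from compound 1 to compound 3 (1.70 log units; beyond the scatter). Compound 3 is expected to give about 30 nM in this assay, within a range of 3 nM to 300 nM.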

Compound 3, half-maximal inhibitory concentration: 120 nM
Estimate against measurement, compound 3: 4.0-fold (0.60 log units) below; the range from low to high includes it.
By their numbers in this assay, from the lowest: compound 2; then compound 3; then compound 1.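

In this assay, for the compounds shown here, the exchange of 4-methoxyphenyl for 3-chlorophenyl is the first change that can be read on its own, and it gives a 13-fold lower number from compound 1 to compound 3 (1.10 log units; beyond the scatter). This shows that the aromatic group on an oxygen on a saturated carbon has a large bearing on the number, since the rest of compound 1 stays the same in compound 3. The two group names also show that the exchange alters both the ring substituent and its numbered ring position, and nothing measured here gives a reason for the step.

The compounds shown leave open how much of the step comes from the change of substituent and how much from the change of ring position, a question that a pair such as 4-chlorophenyl and 3-methoxyphenyl could help to settle. Going by these compounds alone, they also leave open how the number would respond to an amine or a carboxylic acid on the aromatic ring, or to a longer chain in place of the one carried by compound 1 and compound 3.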